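Naphthyloxy acetohydrazones: nitro position shift in lipophilicity

The source may report more compounds than this note shows. Statements on the series, on what has been measured and on what is new or still open speak of the compounds shown alone.

Measured compounds:
compound 1 `O=C(COc1cccc2ccccc12)N/N=C/c1ccccc1[N+](=O)[O-]` 3.97
compound 2 `C/C(=N\NC(=O)COc1cccc2ccccc12)c1ccc([N+](=O)[O-])cc1` 3.37
compound 3 `O=C(COc1cccc2ccccc12)N/N=C/c1ccc(F)cc1` 4.16

In a physicochemical assay for lipophilicity, measured as octanol-water partition (a higher number here means a more lipophilic compound, a lower number a more polar compound), compound 2 gives the lowest of the three numbers; compound 1 stands a step higher that lies beyond the scatter, and compound 3 stands further above it, also beyond the scatter. Compound 4 `C/C(=N\NC(=O)COc1cccc2ccccc12)c1cccc([N+](=O)[O-])c1` is not yet measured. Its difference from compound 2: 3-nitrophenyl in place of 4-nitrophenyl on a carbon with a double bond to nitrogen. The 4-nitrophenyl group leaves and 3-nitrophenyl enters; the atoms are the same and only their arrangement changes. Among the compounds with values here, no measured pair shows this exact change. The step from compound 2 to compound 4 is expected to be small, with no clear direction beyond the scatter, estimated as a number 0.03 log units higher from compound 2 to compound 4 (within the scatter). Compound 4 is therefore estimated at 3.4 in this assay, within 3.05 to 3.75.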

Compound 4, partition coefficient: 3.37
The estimate for compound 4 lay 0.03 log units above the measured number; low and high end bracket the measured number.
By their numbers in this assay, from the lowest: compounds 2 and 4 (each within the scatter of the next); then compounds 1 and 3 (each within the scatter of the next).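

Replacing 4-nitrophenyl with 3-nitrophenyl on a carbon with a double bond to nitrogen gives, in this assay, no change at the digits printed from compound 2 to compound 4 (within the scatter). Within the data shown here, this is the first step between compounds that differ in one place, and this rearrangement of the same atoms does not separate the two compounds in this read-out. Nothing available accounts for this result.

On these data alone, whether an amine or a carboxylic acid in place of the nitro group would give a step beyond the scatter remains open. Compound 1 and compound 3 each differ from compound 2 in more than one place, so the separate contribution of each difference cannot be read.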